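Ethyl Extension on the Sulfur Chain and Macrophage Cytotoxicity

The source may report more compounds than this note shows. Statements on the series, on what has been measured and on what is new or still open speak of the compounds shown alone.

Three compounds of this series have been examined in an ADME assay (MDM cells, Homo sapiens) for cytotoxicity, read by resazurin assay, with a stated time of 3 days; on this read-out lower numbers stand for stronger inhibition and higher numbers for weaker inhibition. Compound 1 `CCCSc1nnc(COc2ccccc2C2=NOC(c3ccc(Cl)cc3Cl)C2)n1NC(=O)c1ccccc1` gives 14.8 ug/mL in this assay. Compound 2 `CCSc1nnc(COc2ccccc2C2=NOC(c3ccc(Cl)cc3Cl)C2)n1NC(C)=O` gives 9.7 ug/mL in this assay. Compound 3 `CSc1nnc(COc2ccccc2C2=NOC(c3ccc(Cl)cc3Cl)C2)n1NC(=O)c1ccccc1` gives 2.2 ug/mL in this assay.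

Compound 3 and compound 1 differ in a single place: ethyl in place of hydrogen on a saturated chain carbon bound to a sulfur. This change brought a 6.7-fold higher number from compound 3 to compound 1 (0.83 log units; beyond the scatter). Compound 2 stands nearest to compound 1, at a gap that lies within the scatter, and apart from compound 3 at a gap beyond the scatter. The difference between the cores of compound 2 and compound 3 is not broken down here.

Compound 4 `CCCCSc1nnc(COc2ccccc2C2=NOC(c3ccc(Cl)cc3Cl)C2)n1NC(C)=O` has not yet been measured in this assay. It differs from compound 2 by ethyl in place of hydrogen on a saturated chain carbon, two bonds along the chain from a sulfur. Among the measured compounds shown here, this is the same kind of change as the one from compound 3 to compound 1, but the place is not the same: in the earlier pair the ethyl enters on a saturated chain carbon bound to a sulfur, whereas here it enters on a saturated chain carbon two bonds along the chain from a sulfur. Resting on the single earlier step of a 6.7-fold higher number from compound 3 to compound 1 (0.83 log units; beyond the scatter), compound 4 is expected to show a 2.3-fold higher number from compound 2 to compound 4 (0.36 log units; beyond the scatter) in this assay, a smaller step than the earlier one given the differing place and the lone example. Compound 4 is accordingly estimated at 22 ug/mL in this assay, expected to fall between 9 ug/mL and 55 ug/mL.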

Compound 4, half-maximal inhibitory concentration: 2.6 ug/mL
Estimate against measurement, compound 4: 8.5-fold (0.93 log units) above; the measured number lies below the stated range.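

In this assay, the ethyl extension moved the number the opposite way this time, a 3.7-fold lower number from compound 2 to compound 4 (0.57 log units; beyond the scatter), and the two steps now on record disagree in direction and differ clearly in size: the same change on two cores in this assay, a 6.7-fold higher number (0.83 log units; beyond the scatter) from compound 3 to compound 1 and a 3.7-fold lower number (0.57 log units; beyond the scatter) from compound 2 to compound 4, 25-fold (1.40 log units) apart, beyond the scatter of two such steps This shows that, within these four compounds, the result of this change on one core cannot simply be carried to another, neither as a direction nor as a size. It does not show why the two steps part, since the pairs differ both in their core and in the place of the change, on a saturated chain carbon bound to a sulfur in one pair and two bonds along the chain from a sulfur in the other, and with a single step for each, these two differences cannot be separated from each other.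

The compounds shown leave open whether a longer chain, such as pentyl or hexyl on the sulfur, would continue the fall seen at butylsulfanyl or reverse it, and whether an amine or a carboxylic acid at the end of that chain would change the picture. Also open, on these data alone, is how the two amide groups compare when the sulfur chain is held the same.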